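The compounds below may be only part of what the source reports. "The series", "measured", "known", "first", "only" and "open" are said of these compounds alone.

Compound 2 `O=C(NCCC1CCCc2ccccc21)c1ccc(OC(F)(F)F)cc1` gives in a functional assay on HEK293 cells for antagonist activity at transient receptor potential cation channel subfamily V member 1 (Homo sapiens), read by calcium flux (on this read-out higher numbers stand for weaker inhibition and lower numbers for stronger inhibition), the highest of the two numbers seen so far, 5400 nM; the nearest point is compound 1 `O=C(Nc1ccc(I)cc1)c1ccc(OC(F)(F)F)cc1`, which in this assay gives 280 nM, a gap beyond the scatter. Compound 3 `O=C(NCCC1CCCc2ccc(O)cc21)c1ccc(OC(F)(F)F)cc1` differs from compound 2 by one change: hydroxy in place of hydrogen on an aromatic carbon. Within the data shown here, no measured pair with this change is available, so its effect cannot be read from the data; a step of modest size is expected, direction uncertain, leaning toward a lower number. Compound 3 is estimated at 3000 nM in this assay, range 800 nM to 12000 nM, an expected step of a 1.8-fold lower number from compound 2 to compound 3 (0.26 log units; within the scatter).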

Compound 3, half-maximal inhibitory concentration: 1350 nM
Beside the measured number, compound 3's estimate is 2.2-fold (0.35 log units) above it; measured number inside the range.
By their numbers in this assay, from the lowest: compound 1; then compound 3; then compound 2.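

In this assay, among these compounds, hydroxy in place of hydrogen on this aromatic carbon, meta to a fused ring and para to a fused ring, gives a 4.0-fold lower number from compound 2 to compound 3 (0.60 log units; beyond the scatter), the first step that can be read for a single change. This carbon therefore takes a substituent with a gain in inhibition beyond the scatter. No measurement shown accounts for the step.

Still open, as far as these compounds go, is whether a methoxy, an amine or a carboxylic acid on this carbon would move the number the same way. Also open, from the compounds shown here alone, is whether hydroxy on the other carbons of this ring would do so.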